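The source may hold more compounds than are shown below. What is called first, only, known or untested is meant among the compounds shown, and "the series" means these compounds.

Compound 1, `CN(C)c1ncnc2c1c(-c1ccoc1)cn2[C@@H]1O[C@H](CO)[C@@H](O)[C@H]1O`: in an ADME assay on MRC5 cells (Homo sapiens), read by MTT assay, with a stated time of 72 h (a lower number here means a stronger inhibitor, a higher number a weaker inhibitor), compound 1 gives only a limit, > 100000 nM.
Compound 2, `Cc1ncnc2c1c(-c1cccs1)cn2[C@@H]1O[C@H](CO)[C@@H](O)[C@H]1O`: in this assay compound 2 gives only a limit, > 100000 nM.
Compound 3, `CSc1ncnc2c1c(-c1cccs1)cn2[C@@H]1O[C@H](CO)[C@@H](O)[C@H]1O`: in this assay compound 3 gives only a limit, > 100000 nM.

None of the three measured compounds returns a number; each sits at the same limit of this assay, described by the limit of > 100000 nM in this assay, at which 3 of the 3 values shown sit. Among the measured compounds shown here, compound 3 therefore stands nowhere above or below the others, and the one single-point change among the measured compounds, a step that the two limits leave unreadable from compound 2 to compound 3, cannot be read in size because both of its ends are limits.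

The next compound, compound 4, `CN(C)c1ncnc2c1c(-c1cccs1)cn2[C@@H]1O[C@H](CO)[C@@H](O)[C@H]1O`, differs from compound 3 in one place: dimethylamino in place of methylsulfanyl on an aromatic carbon. Compound 1 also carries a dimethylamino group at that place, and it too sits at the limit. No measured step therefore gives a readable size for this kind of change, and nothing among the shown values points in either direction.

Compound 4 is expected to behave like its neighbours, with a number no higher from compound 3 to compound 4 (the limit leaves the size open) not readable beyond the scatter. The estimate for compound 4 in this assay is 100000 nM, between 50000 nM and 300000 nM, most likely reported again only as a limit.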

Compound 4, half-maximal inhibitory concentration: > 100000 nM
Compound 4 gave a limit, no number; the forecaster's own chance of this, stated with the estimate: 85%; the middle value lies on the limit itself.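

In this assay compound 4 gives only a limit, > 100000 nM. Its steps from compound 1, compound 2 and compound 3 cannot be read in size, because both ends of each step are limits: the limit of > 100000 nM in this assay, at which 4 of the 4 values shown sit.

The compounds shown leave open whether any of these single changes shifts the true value in this assay at all.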